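The compounds below may be only part of what the source reports. "The series", "measured", "known", "first", "only" and "open" are said of these compounds alone.

The series rests on one shared core, carried by compound 1 `CC1=C(/C=C/C(=O)/C=C/c2ccccc2)C(C)(C)CCC1O`. In a functional assay on CWR22R cells (Homo sapiens) for cytotoxicity, read by MTT assay, with a stated time of 72 h (a lower number here means a stronger inhibitor, a higher number a weaker inhibitor), compound 1 gives 8000 nM. Compound 2 `CC1=C(/C=C/C(=O)/C=C/c2cccc(C)c2)C(C)(C)CCC1O` gives 4400 nM in this assay, and compound 3 `CC1=C(/C=C/C(=O)/C=C/c2cccc(C#N)c2)C(C)(C)CCC1O` gives 2200 nM. Compound 3 thus has the lowest of the three numbers; compound 2 lies nearest to it, within the scatter, while compound 1 lies furthest, beyond it. The steps behind this are a 1.8-fold lower number from compound 1 to compound 2 (0.26 log units; within the scatter), a 3.6-fold lower number from compound 1 to compound 3 (0.56 log units; beyond the scatter) and a 2.0-fold lower number from compound 2 to compound 3 (0.30 log units; within the scatter). Only the cyano step from compound 1 to compound 3 clears the scatter, and it does so modestly.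

Compound 4 `CC1=C(/C=C/C(=O)/C=C/c2cccc([N+](=O)[O-])c2)C(C)(C)CCC1O` carries the change (nitro in place of cyano on an aromatic carbon). Going by the values given here, no measured pair swaps one polar substituent for another at this position; the two steps that introduce cyano show that a group at this aromatic carbon moves the number by at most a modest amount, and the step from methyl to cyano stays within the scatter. The expected step for compound 4 in this assay is therefore a 1.1-fold lower number from compound 3 to compound 4 (0.04 log units; within the scatter), not beyond the scatter. For compound 4 the estimate in this assay is 2000 nM, expected to fall between 900 nM and 4500 nM.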

Compound 4, half-maximal inhibitory concentration: 1900 nM
Compound 4: middle estimate off by 1.1-fold (0.02 log units), on the high side; measured number inside the range.
By their numbers in this assay, from the lowest: compounds 4, 3, 2 and 1 (each within the scatter of the next, the first and the last beyond it).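

Cyano and nitro on this aromatic carbon, meta to a large group, cannot be told apart in this assay, with a 1.2-fold lower number from compound 3 to compound 4 (0.06 log units; within the scatter) within the scatter even though the two groups differ in their atoms and hydrogen-bond acceptors. Compound 3 stood within the scatter of compound 2, whereas nitro separates from methyl, with a 2.3-fold lower number from compound 2 to compound 4 (0.36 log units; beyond the scatter) as a modest step, and nitro also separates from hydrogen, with a 4.2-fold lower number from compound 1 to compound 4 (0.62 log units; beyond the scatter) as a second modest step, so cyano is no longer the only group shown to clear the scatter against hydrogen, while methyl in compound 2 still does not. Nothing measured here accounts for why cyano and nitro give such similar numbers or why methyl stays within the scatter of hydrogen.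

The compounds shown carry only hydrogen, methyl, cyano and nitro at this one aromatic carbon, so it stays open whether an amine or a carboxylic acid there would fit alongside them in this assay or fall well outside their narrow span. From the compounds shown here alone, it also stays open whether nitro would give a similar number on another carbon of the same ring.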